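Trading a dimethylaminoethyl arm for a cyclopropylmethyl arm

The source may report more compounds than this note shows. Statements on the series, on what has been measured and on what is new or still open speak of the compounds shown alone.

Measured so far in an assay on IMR-32 cells for displacement of a labelled ligand from corticotropin-releasing factor receptor 1 (Homo sapiens), read by scintillation counting, with a stated time of 2 h; a lower number here means a stronger inhibitor, a higher number a weaker inhibitor:
compound 1, `CCc1nc(-c2ccc(Cl)cc2Cl)c(CC)nc1NC(C1CC1)C1CC1`: 3.7 nM
compound 2, `CCCN(CCN(C)C)c1nc(CC)c(-c2ccc(Cl)cc2Cl)nc1CC`: 1540 nM

Among the compounds with values here, compound 2 stands at the high end of these two numbers, which makes it the weaker inhibitor of the pair; its only neighbour is compound 1, and the step between them, a 420-fold higher number from compound 1 to compound 2 (2.62 log units; beyond the scatter), is large. That step swaps the whole amine substituent on the shared core, so it says only that the amine substituent matters a great deal here.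

Compound 3, `CCCN(CC1CC1)c1nc(CC)c(-c2ccc(Cl)cc2Cl)nc1CC`, keeps the propyl arm of compound 2 and changes the other arm: cyclopropyl in place of (dimethylamino)methyl on a saturated chain carbon bound to a nitrogen on an aromatic ring. Within the data shown here, it thus sits between compound 2 and compound 1 in this respect: it regains a cyclopropyl ring, but not the dicyclopropylmethyl group of compound 1, and no measured step covers exactly this change.

On that basis compound 3 is expected to be a stronger inhibitor than compound 2, with an estimated step of a 10-fold lower number from compound 2 to compound 3 (1.01 log units; beyond the scatter), in the direction of compound 1 but falling well short of it. The estimate for compound 3 in this assay is 150 nM, within a range of 30 nM to 800 nM.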

Compound 3, inhibition constant: 19.2 nM
The estimate for compound 3 lay 7.8-fold (0.89 log units) above the measured number; measured number outside the range, below it.
By their numbers in this assay, from the lowest: compound 1; then compound 3; then compound 2.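

In this assay, changing only one arm, with cyclopropyl in place of (dimethylamino)methyl on a saturated chain carbon bound to a nitrogen on an aromatic ring, gives an 80-fold lower number from compound 2 to compound 3 (1.90 log units; beyond the scatter) and so recovers most of the distance to compound 1. The earlier comparison replaced the whole amine substituent, whereas this one ties a large share of that loss to the 2-(dimethylamino)ethyl arm, with the propyl arm left in place. The remaining difference is a 5.2-fold higher number from compound 1 to compound 3 (0.72 log units; beyond the scatter), a modest step that is still beyond the scatter, but (cyclopropylmethyl)(propyl)amino and (dicyclopropylmethyl)amino differ as whole substituents, so this step cannot be assigned to any single part of them. No measurement is available to explain why either change shifts binding to this extent.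

The compounds shown leave open whether the gain from compound 2 to compound 3 depends on the cyclopropyl ring itself or mainly on the departure of the dimethylamino group, a question that an isobutyl or cyclobutyl group on the same chain carbon could help to settle. They also leave open how much the amine hydrogen of compound 1 contributes, which a secondary amine carrying a single cyclopropylmethyl group could help to separate from the effect of the remaining arms.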